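The source may hold more compounds than are shown below. What is called first, only, known or untested is meant among the compounds shown, and "the series" means these compounds.

Measured in a functional assay on HepG2 cells (Homo sapiens), read by MTT assay, with a stated time of 48 h; on this read-out higher numbers stand for weaker inhibition and lower numbers for stronger inhibition:
- compound 1 `CCN(CC)CCNC(=O)c1ccc(C(CC)(CC)c2ccc(OCC(O)C(C)(C)C)c(C)c2)n1CC`: 490 nM
- compound 2 `CCn1c(C(=O)NCCCN(C)C)ccc1C(CC)(CC)c1ccc(OCC(O)C(C)(C)C)c(C)c1`: 360 nM
- compound 3 `CCn1c(C(=O)N(C)CCC#N)ccc1C(CC)(CC)c1ccc(OCC(O)C(C)(C)C)c(C)c1`: > 50000 nM (a limit)

Compound 1 and compound 2 lie within the scatter of each other, as a 1.4-fold lower number from compound 1 to compound 2 (0.13 log units; within the scatter) shows. Compound 3 stands at the limit of > 50000 nM in this assay, at which 1 of the 3 values shown sits, which is a limit and not a number.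

Compound 4 `C=CCN(C)C(=O)c1ccc(C(CC)(CC)c2ccc(OCC(O)C(C)(C)C)c(C)c2)n1CC` differs from compound 3 in one place: vinyl in place of cyanomethyl on a saturated chain carbon bound to an amide-type nitrogen. In words, the 2-cyanoethyl group gives way to allyl, leaving an allyl(methyl)amino group on the carbonyl.

Among the compounds with values here, no measured step covers this swap directly. The nearest are the two large steps that lead to compound 3: an at least 100-fold higher number from compound 1 to compound 3 (2.00 log units; beyond the scatter) and an at least 130-fold higher number from compound 2 to compound 3 (2.14 log units; beyond the scatter). In both, a chain ending in diethylamino or dimethylamino is lost, and compound 4 lacks such a chain too. In this assay, a step beyond the scatter is therefore not expected, and compound 4 should stay close to the limit reached by compound 3 in an at least 130-fold higher number from compound 2 to compound 3 (2.14 log units; beyond the scatter).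

The estimated step is a number no higher from compound 3 to compound 4 (the limit leaves the size open).

For compound 4 the expected value is 50000 nM, with an estimated range of 15000 nM to 80000 nM.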

Compound 4, half-maximal inhibitory concentration: > 50000 nM
Compound 4: only a limit was reported; the forecaster's own chance of this, stated with the estimate: 70%; the middle value sits exactly at the limit.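

Compound 4, like compound 3, ends at a limit and not a number in this assay: the limit of > 50000 nM in this assay, at which 2 of the 4 values shown sit.

The step from compound 3 to compound 4 therefore cannot be read. Even so, the large loss also appears with allyl in place of 2-cyanoethyl, with an at least 130-fold higher number from compound 2 to compound 4 (2.14 log units; beyond the scatter) and an at least 100-fold higher number from compound 1 to compound 4 (2.00 log units; beyond the scatter), so among these compounds it does not depend on the nitrile.

Going by these compounds, what stays open is which part of the change counts, as compound 3 and compound 4 have lost both the terminal amine and the amide hydrogen. A 3-(dimethylamino)propyl chain on an amide nitrogen that also carries methyl, or an allyl group on an amide that keeps its hydrogen, would separate the two.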